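This account rests on a few compounds, and the source may have more. Where it says the series, first, only, none or still open, it means among the compounds named here.

Values in a functional assay on MCF7 cells (Homo sapiens) for inhibition, read by sulforhodamine B assay; a lower number here means a stronger inhibitor, a higher number a weaker inhibitor:
- Compound 1 `Cc1ccc(NC2=CC(=O)c3c(nc4n3[C@H]3OC[C@@H](O)[C@H]3OC4)C2=O)cc1C`: 4950 nM
- Compound 2 `CCOc1ccc(NC2=CC(=O)c3c(nc4n3[C@H]3OC[C@@H](O)[C@H]3OC4)C2=O)cc1`: > 4000 nM, a limit of the assay and not a number
- Compound 3 `COc1cccc(NC2=CC(=O)c3c(nc4n3[C@H]3OC[C@@H](O)[C@H]3OC4)C2=O)c1`: 3830 nM

All three compounds share one core and differ only in the aromatic group on an amine nitrogen. Compound 3, at 3830 nM, is not clearly separated from the other compound with a true number, as the measured step is a 1.3-fold lower number from compound 1 to compound 3 (0.11 log units; within the scatter). Compound 2 gives > 4000 nM, which is only a limit. The comparison with that limit gives an at least 1.0-fold lower number from compound 2 to compound 3 (0.01 log units; that floor lies within the scatter), while the remaining pair gives a step that the limit leaves unreadable from compound 1 to compound 2.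

Compound 4 `CCCc1ccc(NC2=CC(=O)c3c(nc4n3[C@H]3OC[C@@H](O)[C@H]3OC4)C2=O)cc1` carries 4-propylphenyl in place of 3-methoxyphenyl on an amine nitrogen. Every readable exchange of this group so far has stayed within the scatter, so no step beyond the scatter is expected in this assay, and no direction can be favoured. That expectation rests on three compounds only, so it is a loose one. The 4-ethoxyphenyl of compound 2 is the closest group by name, so compound 4 might also be expected to return only a limit. The expected change is a 1.2-fold higher number from compound 3 to compound 4 (0.07 log units; within the scatter). For compound 4 the estimated value is 4500 nM, with an expected range from 2200 nM to 9000 nM.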

Compound 4, half-maximal inhibitory concentration: > 4000 nM
Compound 4 ended at the assay's limit; the forecaster's own chance of this, stated with the estimate: 25%; the middle value is on the limit's open side.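

In this assay, 4-propylphenyl puts a group made of carbon only on the amine nitrogen, with no hydrogen-bond acceptor, where 3-methoxyphenyl carries one, and the readable comparison is an at least 1.0-fold higher number from compound 3 to compound 4 (0.01 log units; that floor lies within the scatter). Going by these compounds alone, this small floor means that the exchange gives no step that can be told from the scatter, yet it does not fix the true size of the step, and the steps to compound 4 from compound 1 and from compound 2 cannot be read. Compound 4 gives a limit and not a number, and it is the second compound in this small set to do so, which shows that an all-carbon group and an oxygen-bearing group can both end there: the limit of > 4000 nM in this assay, at which 2 of the 4 values shown sit.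

On these data alone, how far the true values of compound 2 and compound 4 lie from that limit remains open, so these two cannot be placed relative to each other. Also open, as far as these compounds go, is how an amine or a carboxylic acid on the phenyl ring, or a chain longer than propyl, would read in this assay.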